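Swapping the Morpholine Ring for Pyrrolidine in Compound 1

The compounds below may be only part of what the source reports. "The series", "measured", "known", "first", "only" and "open" are said of these compounds alone.

Three compounds have been measured in a functional assay on A-431 cells (Homo sapiens) for cytotoxicity, read by MTT assay, with a stated time of 72 h, tested at 100 uM; a lower number here means less inhibition of growth, a higher number more inhibition of growth at the concentration tested:
- compound 1 `N/C(=N\NC(=S)N1CCOCC1)c1ccccn1` gives 84.6%
- compound 2 `Cc1ccnc(/C(N)=N/NC(=S)N2CCOCC2)c1` gives 82.8%
- compound 3 `Cc1cccc(/C(N)=N/NC(=S)N2CCOCC2)n1` gives 84.8%

All three values sit close together. Compound 1 differs from the other two by steps that are both within the scatter: a number 1.8 percentage points lower from compound 1 to compound 2 (within the scatter) and a number 0.2 percentage points higher from compound 1 to compound 3 (within the scatter). Each of these steps adds a methyl in place of hydrogen on an aromatic carbon, and neither moves the number noticeably.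

Compound 4 `N/C(=N\NC(=S)N1CCCC1)c1ccccn1` has not been measured. It differs from compound 1 in one place: pyrrolidin-1-yl in place of morpholin-4-yl on a thiocarbonyl carbon. This change sits far from the aromatic ring that the two measured steps touched, so those steps say little about it; nothing measured here tests a change on the thiocarbonyl carbon. What the data do show is that the shared core keeps a high value across three variations. In this assay compound 4 is therefore expected to land near compound 1, at 80%, within a range from 62% to 92%. The step this estimate implies is a number 4.6 percentage points lower from compound 1 to compound 4 (within the scatter), which is expected to stay within the scatter, though with wider uncertainty than the measured steps.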

Compound 4, percent growth inhibition at one concentration: 83.8%
Estimate against measurement, compound 4: 3.8 percentage points below; low and high end bracket the measured number.
By their numbers in this assay, from the lowest: compounds 2, 4, 1 and 3 (each within the scatter of the next).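

In this assay, pyrrolidin-1-yl in place of morpholin-4-yl on a thiocarbonyl carbon gives a number 0.8 percentage points lower from compound 1 to compound 4 (within the scatter). For the compounds shown here, this is the first look at this position, and it shows that the ring can shrink from six-membered to five-membered and lose its oxygen and its hydrogen-bond acceptor without the number leaving the scatter. No available measurement speaks to why the two groups give such close numbers.

Both groups are non-aromatic rings attached through their nitrogen, so this step says nothing about an open-chain group such as dimethylamino or a longer chain such as dibutylamino at this place. It also leaves open what a phenyl ring or a carboxylic acid on a ring at this position would do to the number.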